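The source may report more compounds than this note shows. Statements on the series, on what has been measured and on what is new or still open speak of the compounds shown alone.

Compound 1 `CN(C)CC1CCC/C(=C\c2ccc(OC(=O)/C=C/c3ccccc3)cc2)C1=O` gives 39500 nM in a functional assay on MOLT-4 cells (Homo sapiens); on this read-out lower numbers stand for stronger inhibition and higher numbers for weaker inhibition. Among the measured compounds shown here, compound 2 `CN(C)CC1CCC/C(=C\c2ccc(OC(=O)/C=C/c3ccc(Cl)c(Cl)c3)cc2)C1=O` gives 4570 nM in this assay, the lowest of the two numbers so far; the step of an 8.6-fold lower number from compound 1 to compound 2 (0.94 log units; beyond the scatter) came with 3,4-dichlorophenyl in place of phenyl on a double-bonded chain carbon bound to a double-bonded chain carbon. Compound 3 `CN(C)CC1CCC/C(=C\c2ccc(OC(=O)c3ccc(Cl)cc3)cc2)C1=O` is not yet measured; against compound 2 the change is 4-chlorophenyl in place of 2-(3,4-dichlorophenyl)ethenyl on a carbonyl carbon. For the measured compounds named here, only the step from compound 1 to compound 2 bears on this, and only on the chlorines; no measured step covers loss of the double bond outside aromatic rings. Compound 3 keeps one of the two chlorines, so a step of a 2.6-fold higher number from compound 2 to compound 3 (0.42 log units; beyond the scatter) toward a higher number is expected. Compound 3 is estimated at 12000 nM, range 4000 nM to 40000 nM.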

Compound 3, half-maximal inhibitory concentration: 5110 nM
Estimate against measurement, compound 3: 2.3-fold (0.37 log units) above; low and high end bracket the measured number.
By their numbers in this assay, from the lowest: compounds 2 and 3 (each within the scatter of the next); then compound 1.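

At the carbonyl carbon, a 1.1-fold higher number from compound 2 to compound 3 (0.05 log units; within the scatter) in this assay came with 4-chlorophenyl in place of 2-(3,4-dichlorophenyl)ethenyl, so this group swap, which removes one chlorine and the double bond outside aromatic rings, stays within the scatter. With 4-chlorophenyl in place of 2-phenylethenyl, a 7.7-fold lower number from compound 1 to compound 3 (0.89 log units; beyond the scatter) shows that a lower number than that of the unchlorinated compound 1 does not require the double bond outside aromatic rings. Open, from the compounds shown here alone, is whether unsubstituted phenyl or 4-methoxyphenyl on the carbonyl carbon would give a number close to that of 4-chlorophenyl. No supporting evidence is available to explain these steps.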